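From 2-fluorophenyl to 4-chlorophenyl: an expected step

A few compounds are considered here, and "the series" means these few. Any claim that something is new, unique, unknown or untested is made for them only; others in the source may bear on it.

In a functional assay on OVCAR-3 cells (Homo sapiens) for antiproliferative activity, read by MTT assay, with a stated time of 24 h (a higher number here means a weaker inhibitor, a lower number a stronger inhibitor), compound 3 `O=c1[nH]cc(S(=O)(=O)Nc2cccc(-c3cn(-c4ccccc4F)nn3)c2)c(=O)[nH]1` gives 12500 nM, the highest of the three numbers. Compound 2 `Cc1ccccc1-n1cc(-c2cccc(NS(=O)(=O)c3c[nH]c(=O)[nH]c3=O)c2)nn1` gives 6230 nM, and compound 1 `Cc1cccc(-n2cc(-c3ccccc3NS(=O)(=O)c3c[nH]c(=O)[nH]c3=O)nn2)c1` gives 3150 nM. Going by the values given here, the one single-site step measured so far, a 2.0-fold higher number from compound 2 to compound 3 (0.30 log units; within the scatter), lies within the scatter. Compound 4 `O=c1[nH]cc(S(=O)(=O)Nc2cccc(-c3cn(-c4ccc(Cl)cc4)nn3)c2)c(=O)[nH]1` differs from compound 3 by 4-chlorophenyl in place of 2-fluorophenyl on an aromatic nitrogen. Among the compounds with values here, no measured step exchanges one halogen for another on this aromatic nitrogen, so the expectation rests only on a 2.0-fold higher number from compound 2 to compound 3 (0.30 log units; within the scatter), a change on the same group that left the number essentially unchanged. The step expected for compound 4 is therefore a 1.4-fold lower number from compound 3 to compound 4 (0.14 log units; within the scatter), not beyond the scatter. The estimate for compound 4 in this assay is 9000 nM, in the range 3000 nM to 30000 nM.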

Compound 4, half-maximal inhibitory concentration: 2040 nM
Compound 4: the middle estimate sits 4.4-fold (0.64 log units) above what was measured, outside the stated range (below it).
By their numbers in this assay, from the lowest: compounds 4, 1, 2 and 3 (each within the scatter of the next, the first and the last beyond it).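

In this assay the change to 4-chlorophenyl gives a 6.1-fold lower number from compound 3 to compound 4 (0.79 log units; beyond the scatter) and a 3.1-fold lower number from compound 2 to compound 4 (0.48 log units; beyond the scatter) so the group on this aromatic nitrogen can move the number beyond the scatter, which a 2.0-fold higher number from compound 2 to compound 3 (0.30 log units; within the scatter) did not show. Each of these changes alters both the substituent and its place on the phenyl ring, so the two contributions cannot be separated. Nothing available explains the drop in the number. Still open, from the compounds shown here alone, is whether 2-chlorophenyl or 4-fluorophenyl would separate them, and whether 4-aminophenyl or 4-carboxyphenyl would keep the lower number.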